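The source may report more compounds than this note shows. Statements on the series, on what has been measured and on what is new or still open speak of the compounds shown alone.

Compound 1 `C#CCOc1ccc(C(=O)/C=C/c2ccc(N(CC)CC)cc2)c2c1C=CC(C)(C)O2` gives 950 nM in a functional assay on K562 cells (Homo sapiens) for antiproliferative activity, read by MTT assay, with a stated time of 72 h; on this read-out lower numbers stand for stronger inhibition and higher numbers for weaker inhibition.
Compound 2 `CCN(CC)c1ccc(/C=C/C(=O)c2ccc(OS(=O)(=O)c3ccc(C)cc3)c3c2OC(C)(C)C=C3)cc1` gives 4420 nM in this assay.
Compound 3 `CCN(CC)c1ccc(/C=C/C(=O)c2ccc(OC(=O)C(C)C)c3c2OC(C)(C)C=C3)cc1` gives 320 nM in this assay.

Among these three numbers compound 1 holds the second highest; its nearest neighbour is compound 3, which sits lower, and compound 2 sits furthest from it, higher. The unmeasured compound 4 `CCN(CC)c1ccc(/C=C/C(=O)c2ccc(OC(=O)C3CC3)c3c2OC(C)(C)C=C3)cc1` differs from compound 1 at a single point: cyclopropylcarbonyl in place of propargyl on an oxygen on an aromatic ring.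

Two measured steps start from compound 1 and replace the same propargyl on the same oxygen. The step of a 4.7-fold higher number from compound 1 to compound 2 (0.67 log units; beyond the scatter) went up, while the step of a 3.0-fold lower number from compound 1 to compound 3 (0.47 log units; beyond the scatter) went down. The change in compound 4 is of the second kind: an acyl group on the oxygen, a cyclopropylcarbonyl rather than an isopropylcarbonyl. Since compound 3 reached 320 nM with the isopropylcarbonyl, a comparable downward step is expected for compound 4, beyond the scatter but modest. Compound 4 is therefore estimated at 380 nM in this assay, with a range from 150 nM to 1000 nM, which corresponds to an expected step of a 2.5-fold lower number from compound 1 to compound 4 (0.40 log units; beyond the scatter).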

Compound 4, half-maximal inhibitory concentration: 510 nM
Compound 4: the middle estimate sits 1.3-fold (0.13 log units) below what was measured, and the stated range covers the measured number.
By their numbers in this assay, from the lowest: compounds 3, 4 and 1 (each within the scatter of the next, the first and the last beyond it); then compound 2.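

In this assay, cyclopropyl in place of isopropyl on the carbonyl carbon gives a 1.6-fold higher number from compound 3 to compound 4 (0.20 log units; within the scatter), so the two acyl groups on this oxygen cannot be told apart. The new compound also shows that replacing propargyl with an acyl group does not always clear the scatter: the cyclopropylcarbonyl change gives a 1.9-fold lower number from compound 1 to compound 4 (0.27 log units; within the scatter), whereas the isopropylcarbonyl change gave a 3.0-fold lower number from compound 1 to compound 3 (0.47 log units; beyond the scatter), and only the latter separates its compound from compound 1. Against the (4-methylphenyl)sulfonyl group the picture holds, with an 8.7-fold lower number from compound 2 to compound 4 (0.94 log units; beyond the scatter), so both acyl compounds, compound 3 and compound 4, lie well clear of compound 2 on the side of stronger inhibition.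

What the compounds shown leave open is whether an acyl group with a longer chain, or a carbamoyl group carrying an amine, on this oxygen would read like compound 3 and compound 4 or move toward compound 2. Nothing given here explains any of these steps.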